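Pyridin-4-yl in Place of Phenyl on Compound 1

The source may report more compounds than this note shows. Statements on the series, on what has been measured and on what is new or still open speak of the compounds shown alone.

Measured so far:
- compound 1 `O[C@@H](c1ccccc1)[C@H]1CO[C@H](c2ccccc2)[C@@H](C/C=C/c2ccccc2)C1`: 6060 nM
- compound 2 `COc1ccc(/C=C/C[C@H]2C[C@@H]([C@@H](O)c3ccccc3)CO[C@@H]2c2ccc(OC)c(OC)c2)cc1OC`: 15500 nM

Of the compounds shown here, two sharing one core have been tested in a functional assay on HeLa cells (Homo sapiens) for cytotoxicity, read by WST assay, with a stated time of 48 h; on this read-out lower numbers stand for stronger inhibition and higher numbers for weaker inhibition. Compound 1 gives 6060 nM, the lowest of the two numbers and therefore the stronger inhibition seen so far. Compound 2 gives 15500 nM, a higher number whose gap to compound 1 lies beyond the usual scatter.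

Compound 3 `O[C@@H](c1ccccc1)[C@H]1CO[C@H](c2ccccc2)[C@@H](C/C=C/c2ccncc2)C1` is not yet measured. It differs from compound 1 in one place: pyridin-4-yl in place of phenyl on a double-bonded chain carbon bound to a double-bonded chain carbon. Going by the values given here, no pair of measured compounds shows this kind of exchange, so nothing here says how a phenyl to pyridin-4-yl swap on this chain moves the read-out. The expectation therefore leans on compound 1 alone, with a small step or none beyond the scatter.

Compound 3 is expected to give about 8000 nM, between 2500 nM and 25000 nM, a step of a 1.3-fold higher number from compound 1 to compound 3 (0.12 log units; within the scatter) that is estimated to stay close to compound 1.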

Compound 3, half-maximal inhibitory concentration: > 100000 nM
Compound 3: only a limit was reported (the forecaster's own chance of this, stated with the estimate: 10%); middle value at least 12-fold (1.09 log units) from the limit.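

In this assay, compound 3 gives > 100000 nM, which is a limit of the assay and not a number. Pyridin-4-yl in place of phenyl on this chain keeps the heavy-atom count and adds one hydrogen-bond acceptor, yet this single exchange gives an at least 16-fold higher number from compound 1 to compound 3 (1.21 log units; beyond the scatter), showing for the first time that the read-out is highly sensitive to the ring at this position. The full size of the step cannot be read because compound 3 sits at the limit: the limit of > 100000 nM in this assay, at which 1 of the 3 values shown sits.

The compounds shown do not tell whether any other ring at this position would keep the read-out near that of compound 1, such as pyridin-3-yl or a phenyl carrying a single fluorine. They also leave open whether a nitrogen in this ring always weakens inhibition or only does so in pyridin-4-yl.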